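Changing the benzyl group on sulfur

A few compounds are considered here, and "the series" means these few. Any claim that something is new, unique, unknown or untested is made for them only; others in the source may bear on it.

Compound 1 `COc1ccc2cc([C@H](C)c3nnc(SCc4ccc(Cl)cc4)n3-c3ccc(Cl)cc3)ccc2c1`: 5800 nM
Compound 2 `COc1ccc2cc([C@H](C)c3nnc(SCc4ccc(C)cc4)n3-c3ccc(Cl)cc3)ccc2c1`: 8400 nM

In a functional assay on PC-3 cells (Homo sapiens) for cytotoxicity, read by MTT assay (a higher number here means a weaker inhibitor, a lower number a stronger inhibitor), compound 2 gives 8400 nM. For the measured compounds named here, this lies within the scatter of the only other measured number, so neither compound can be ranked over the other. Compound 3 `COc1ccc2cc([C@H](C)c3nnc(SCc4c(Cl)cccc4Cl)n3-c3ccc(Cl)cc3)ccc2c1` has not yet been measured. It carries the change (2,6-dichlorophenyl in place of 4-methylphenyl on a saturated chain carbon bound to a sulfur), that is, 2,6-dichlorophenyl in place of 4-methylphenyl on a saturated chain carbon bound to a sulfur. Going by the values given here, one measured step bears on this group: a 1.4-fold higher number from compound 1 to compound 2 (0.16 log units; within the scatter). Among the compounds with values here, that step stays within the scatter, but it is a single small substitution, and no measured compound carries 2,6-dichlorophenyl, so the guidance is weak. No clear direction can be drawn from it, and no shift beyond the scatter is expected in this assay. The estimated step is a 1.2-fold lower number from compound 2 to compound 3 (0.08 log units; within the scatter). For compound 3 the expected value is 7000 nM, with an estimated range of 3000 nM to 16000 nM.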

Compound 3, half-maximal inhibitory concentration: 34700 nM
The estimate for compound 3 lay 5.0-fold (0.70 log units) below the measured number; the measured number lies above the stated range.
By their numbers in this assay, from the lowest: compounds 1 and 2 (each within the scatter of the next); then compound 3.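

In this assay the sulfur-bound benzyl group turned out not to be indifferent to change: 2,6-dichlorophenyl in place of 4-methylphenyl gives (a 4.1-fold higher number from compound 2 to compound 3 (0.62 log units; beyond the scatter)), and 2,6-dichlorophenyl in place of 4-chlorophenyl gives (a 6.0-fold higher number from compound 1 to compound 3 (0.78 log units; beyond the scatter)), which makes compound 3 the weakest of the three. The earlier exchange of methyl for chloro had stayed within the scatter (a 1.4-fold higher number from compound 1 to compound 2 (0.16 log units; within the scatter)), so only this replacement of the whole substituted phenyl shows that the position can respond at all. Nothing available explains why compound 3 loses activity here.

The compounds shown leave open whether the loss follows from having two chlorines or from where they stand, as they include no benzyl group carrying a single chlorine and no unsubstituted benzyl. From the compounds shown here alone, it also remains open how this position would respond to something other than a substituted benzyl, such as a longer alkyl chain, an amine or a carboxylic acid on sulfur.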